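From methoxycarbonyl to carboxy: the step to compound 4

The compounds below may be only part of what the source reports. "The series", "measured", "known", "first", "only" and "open" are said of these compounds alone.

Of the compounds shown here, three sharing one core have been measured in a functional assay (aorta) with Rattus norvegicus as the target; a lower number here means a stronger inhibitor, a higher number a weaker inhibitor. Compound 1 `CC1(C)Oc2ccc(C#N)cc2[C@@H](/N=C(\NC#N)Nc2ccccc2)[C@@H]1O` gives 1400 nM; 1300 nM (2 entries), compound 2 `CC1(C)Oc2ccc(C#N)cc2[C@@H](/N=C(\NC#N)Nc2ccc(C(F)(F)F)cc2)[C@@H]1O`, which carries trifluoromethyl, gives 8100 nM, and compound 3 `COC(=O)c1ccc(N/C(=N/[C@@H]2c3cc(C#N)ccc3OC(C)(C)[C@H]2O)NC#N)cc1`, which carries methoxycarbonyl, gives 18400 nM. Compound 3 therefore has the highest number of the three, and compound 2 stands closest to it.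

Compound 4 `CC1(C)Oc2ccc(C#N)cc2[C@@H](/N=C(\NC#N)Nc2ccc(C(=O)O)cc2)[C@@H]1O` differs from compound 3 by a single change: hydrogen in place of methyl on an oxygen next to a carbonyl group, which turns methoxycarbonyl into carboxy (hydrogen in place of methyl on an oxygen next to a carbonyl group). Among the compounds with values here, no measured step makes this exact change. Within the data shown here, the closest evidence is the one measured swap of one such group for another, a 2.3-fold higher number from compound 2 to compound 3 (0.36 log units; beyond the scatter), which is modest in size. Compound 2 and compound 3, which both carry a group where compound 1 has none, also show higher numbers than compound 1. Given a 2.3-fold higher number from compound 2 to compound 3 (0.36 log units; beyond the scatter), a step of similar modest size towards a higher number is expected in this assay, though with only this one step to go on the range must stay wide. The expected change is a 2.2-fold higher number from compound 3 to compound 4 (0.34 log units; beyond the scatter). For compound 4 the estimate is 40000 nM, with an expected range from 10000 nM to 150000 nM.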

Compound 4, half-maximal inhibitory concentration: > 100000 nM
Compound 4: no number, only a limit (the forecaster's own chance of this, stated with the estimate: 25%); middle value at least 2.5-fold (0.39 log units) away from the limit.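

In this assay, compound 4 gives no exact number, only a limit: the limit of > 100000 nM in this assay, at which 1 of the 4 values shown sits. Even so, replacing a single methyl with hydrogen, which turns methoxycarbonyl into carboxy, gives an at least 5.4-fold higher number from compound 3 to compound 4 (0.73 log units; beyond the scatter), so this small edit at the oxygen next to the carbonyl group moves the result beyond the usual scatter. Compared with trifluoromethyl on the same aromatic carbon, carboxy gives an at least 12-fold higher number from compound 2 to compound 4 (1.09 log units; beyond the scatter), a large step that far exceeds the modest gap seen earlier, a 2.3-fold higher number from compound 2 to compound 3 (0.36 log units; beyond the scatter), and puts the three groups in the order trifluoromethyl, methoxycarbonyl, carboxy, with the number rising along that series.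

From the compounds shown here alone, because compound 4 has only a limit, the true size of both new steps remains unknown, and each could be larger than the figure given: the limit of > 100000 nM in this assay, at which 1 of the 4 values shown sits. Going by these compounds, it is also open whether an ethoxycarbonyl group, a carboxamide or a hydroxymethyl group on this aromatic carbon would give a number closer to that of compound 3 or sit near the limit of compound 4.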